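Shortening the Side Chain Toward an Imidazole Headgroup

This account rests on a few compounds, and the source may have more. Where it says the series, first, only, none or still open, it means among the compounds named here.

Three compounds share one core and differ in the side chain and in the substitution of the imide nitrogen. Compound 1 `Cn1cc(C2=C(c3nn(CCn4ccnc4)c4ncccc34)C(=O)NC2=O)c2ccccc21` carries a 2-(1H-imidazol-1-yl)ethyl chain and an unsubstituted imide; in a functional assay on K562 cells (Homo sapiens) for antiproliferative activity, read by MTT assay, with a stated time of 48 h (on this read-out lower numbers stand for stronger inhibition and higher numbers for weaker inhibition), compound 1 reaches only the assay limit of > 100000 nM. Compound 2 `Cn1cc(C2=C(c3nn(CCCCn4ccnc4)c4ncccc34)C(=O)N(c3ccccc3)C2=O)c2ccccc21` carries a phenyl on the imide and a longer imidazolyl chain, and in this assay compound 2 gives 5030 nM. Compound 3 `Cn1cc(C2=C(c3nn(CCCN4CCCCC4)c4ncccc34)C(=O)N(c3ccccc3)C2=O)c2ccccc21` keeps the phenyl and bears a 3-(piperidin-1-yl)propyl chain; in this assay compound 3 gives 3790 nM, the lowest of the two numbers, though the step of a 1.3-fold lower number from compound 2 to compound 3 (0.12 log units; within the scatter) stays within the scatter.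

Compound 4 `Cn1cc(C2=C(c3nn(CCn4ccnc4)c4ncccc34)C(=O)N(c3ccccc3)C2=O)c2ccccc21` is reached from compound 3 by the change (1H-imidazol-1-yl in place of (piperidin-1-yl)methyl on a saturated chain carbon, two bonds along the chain from an aromatic nitrogen). For the measured compounds named here, the one measured step, a 1.3-fold lower number from compound 2 to compound 3 (0.12 log units; within the scatter), shows that the headgroup swap alone hardly matters; the shortening of the chain has no measured counterpart, and compound 1, which carries the same chain as compound 4, shows only a limit (the limit of > 100000 nM in this assay, at which 1 of the 3 values shown sits), while compound 2 with its longer chain gives a number. Compound 4 is therefore expected to come out somewhat weaker than compound 3, with an estimated step of a 3.2-fold higher number from compound 3 to compound 4 (0.50 log units; beyond the scatter). The estimate for compound 4 is 12000 nM, ranging from 3000 nM to 50000 nM.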

Compound 4, half-maximal inhibitory concentration: 26400 nM
Compound 4: the middle estimate sits 2.2-fold (0.34 log units) below what was measured, within the range that was stated.
By their numbers in this assay, from the lowest: compounds 3 and 2 (each within the scatter of the next); then compound 4. At a limit, above all of these: compound 1.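

At the saturated chain carbon two bonds along the chain from an aromatic nitrogen, the 2-(1H-imidazol-1-yl)ethyl chain of compound 4 gives a clearly higher number in this assay than both the 3-(piperidin-1-yl)propyl chain (a 7.0-fold higher number from compound 3 to compound 4 (0.84 log units; beyond the scatter)) and the longer imidazolyl chain (a 5.2-fold higher number from compound 2 to compound 4 (0.72 log units; beyond the scatter)), so with the imidazole kept, chain length now shows a step beyond the scatter, which the earlier change between the two longer chains did not (a 1.3-fold lower number from compound 2 to compound 3 (0.12 log units; within the scatter)). Phenyl in place of hydrogen on the imide nitrogen also turns out to matter on this short chain, and it brings a measurable number (an at least 3.7-fold lower number from compound 1 to compound 4 (0.57 log units; beyond the scatter)). That step has only one firm end, as compound 1 stands at a limit and not at a number: the limit of > 100000 nM in this assay, at which 1 of the 4 values shown sits.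

The compounds shown leave open how the number runs between the two imidazolyl chains, a gap that a 3-(1H-imidazol-1-yl)propyl chain would fill, and whether a 2-(piperidin-1-yl)ethyl chain would lose as much on shortening. They also leave open whether a small alkyl group such as methyl on the imide nitrogen could stand in for phenyl.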